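A few compounds are considered here, and "the series" means these few. Any claim that something is new, unique, unknown or untested is made for them only; others in the source may bear on it.

Measured in a functional assay on L02 cells (Homo sapiens) for inhibition, read by Griess assay, with stated times of 1 h and 24 h; on this read-out lower numbers stand for stronger inhibition and higher numbers for weaker inhibition:
Compound 1 `COc1cc(/C=C/c2nccc(NC(C)C)n2)cc(OC)c1OC`: < 40000 nM
Compound 2 `CC(C)Nc1nc(/C=C/c2ccccc2)nc2ccsc12`: > 1000000 nM

Both entries are limits of the assay and not numbers. Compound 2 stands at > 1000000 nM, which is a limit, so no exact value is available for it. Compound 3 `CCCCNc1nc(/C=C/c2ccccc2)nc2ccsc12` carries butyl in place of isopropyl on a nitrogen on an aromatic ring. Going by the values given here, no measured step shows what such a change does, so only a modest shift toward stronger inhibition is expected in this assay, and the expected change is an at least 2.0-fold lower number from compound 2 to compound 3 (0.30 log units; that floor lies within the scatter). For compound 3 the estimated value is 500000 nM, with an expected range from 60000 nM to 2000000 nM.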

Compound 3, half-maximal inhibitory concentration: > 1000000 nM
Compound 3: only a limit was reported (the forecaster's own chance of this, stated with the estimate: 60%); at least 2.0-fold (0.30 log units) between middle value and limit.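

Going by these compounds alone, compound 2 and compound 3 both give only a limit in this assay, so no step between them can be read. The compounds shown leave open how butyl and isopropyl on that nitrogen actually compare.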